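Bromo for Chloro on a Shared Core: Expectation for Compound 4

This account rests on a few compounds, and the source may have more. Where it says the series, first, only, none or still open, it means among the compounds named here.

Measured compounds:
compound 1, `Cn1c(=O)[nH]c2nc(SCC(=O)c3ccc(Cl)cc3)[nH]c2c1=O`: 6100 nM
compound 2, `Cn1c(=O)[nH]c2nc(SCC(=O)c3ccc(Br)cc3)[nH]c2c1=O`: 9700 nM
compound 3, `Cn1c(=O)[nH]c2nc(SC/C(=N/O)c3ccc(Cl)cc3)[nH]c2c1=O`: 1700 nM

All three were tested in a functional assay on PANC-1 cells (Homo sapiens) for inhibition, read by MTT assay, with a stated time of 48 h; on this read-out higher numbers stand for weaker inhibition and lower numbers for stronger inhibition. Compound 1 and compound 2 differ by bromo in place of chloro on an aromatic carbon, and this change gave a 1.6-fold higher number from compound 1 to compound 2 (0.20 log units; within the scatter). Compound 3 carries a different core from compound 1; the difference between the two cores is not broken down here. In this assay compound 3 is the most potent of the three, standing beyond the scatter from both compound 1 and compound 2.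

Compound 4, `Cn1c(=O)[nH]c2nc(SC/C(=N/O)c3ccc(Br)cc3)[nH]c2c1=O`, has not yet been measured. It differs from compound 3 by bromo in place of chloro on an aromatic carbon, the same change that separates compound 1 from compound 2, at the same place. Compound 4 is expected to show a 1.5-fold higher number from compound 3 to compound 4 (0.17 log units; within the scatter), a step set beside a 1.6-fold higher number from compound 1 to compound 2 (0.20 log units; within the scatter); this expectation rests on the fact that the earlier instance of the change stayed within the scatter. The estimate for compound 4 in this assay is therefore 2500 nM, with a likely range from 1200 nM to 5500 nM.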

Compound 4, half-maximal inhibitory concentration: 2100 nM
Compound 4: middle estimate off by 1.2-fold (0.08 log units), on the high side; measured number inside the range.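

In this assay, bromo in place of chloro on the core of compound 3 gave a 1.2-fold higher number from compound 3 to compound 4 (0.09 log units; within the scatter). Set beside the earlier instance of the change, the new step agrees with it, so on these two cores the change from 4-chlorophenyl to 4-bromophenyl behaved alike: the same change on two cores in this assay, a 1.6-fold higher number (0.20 log units; within the scatter) from compound 1 to compound 2 and a 1.2-fold higher number (0.09 log units; within the scatter) from compound 3 to compound 4, 1.3-fold (0.11 log units) apart, within the scatter of two such steps. This shows that, for this pair of cores, chloro and bromo cannot be told apart on this read-out, but it does not show a true difference between the two halogens, nor that the same would hold on any third core.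

The compounds shown leave open what other groups would do in the place of the halogen, such as fluoro, methoxy, an amine or a carboxylic acid, or a plain hydrogen on the aromatic carbon. They also leave open whether the agreement between the two cores would persist on other cell lines.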